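The source may hold more compounds than are shown below. What is called first, only, known or untested is meant among the compounds shown, and "the series" means these compounds.

Values in a functional assay on HeLa cells (Homo sapiens) for antiproliferative activity, read by MTT assay, with a stated time of 48 h; a higher number here means a weaker inhibitor, a lower number a stronger inhibitor:
- compound 1 `Cc1ccc2[nH]c(-c3cn(-c4ccccc4)nc3-c3ccccc3)nc2c1`: 6560 nM
- compound 2 `FC(F)(F)c1ccc2[nH]c(-c3cn(-c4ccccc4)nc3-c3ccccc3)nc2c1`: 1920 nM
- compound 3 `O=C(OCc1ccccc1)c1ccc2[nH]c(-c3cn(-c4ccccc4)nc3-c3ccccc3)nc2c1`: 21300 nM

Compound 2 has the lowest number of the three, which makes it the strongest inhibitor here. Compound 4 `COc1ccc(-c2nn(-c3ccccc3)cc2-c2nc3cc(C(F)(F)F)ccc3[nH]2)cc1` differs from compound 2 by methoxy in place of hydrogen on an aromatic carbon, turning phenyl into 4-methoxyphenyl. Among the measured compounds shown here, no measured step touches that place. The measured steps change a different group, and they show only how far numbers can move in this small set: a 3.4-fold lower number from compound 1 to compound 2 (0.53 log units; beyond the scatter), and an 11-fold higher number from compound 2 to compound 3 (1.05 log units; beyond the scatter). They give a scale but no direction, so no step beyond the scatter is expected in this assay. The estimated change is a 1.0-fold higher number from compound 2 to compound 4 (0.02 log units; within the scatter). Compound 4 is expected near 2000 nM, with an estimated range of 700 nM to 6000 nM.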

Compound 4, half-maximal inhibitory concentration: 2760 nM
Beside the measured number, compound 4's estimate is 1.4-fold (0.14 log units) below it; the measured number falls inside the stated range.
By their numbers in this assay, from the lowest: compounds 2 and 4 (each within the scatter of the next); then compound 1; then compound 3.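

Among the compounds shown here, the earlier compounds varied a different place, so this is the first reading on the phenyl that becomes 4-methoxyphenyl. In this assay, methoxy in place of hydrogen gives a 1.4-fold higher number from compound 2 to compound 4 (0.16 log units; within the scatter) and so cannot be told apart from repeat-measurement noise: this place holds methoxy with no detectable loss. No measurement shown here accounts for this result. One group cannot show a trend, and an amine or a carboxylic acid in the same place could still move the number. From the compounds shown here alone, whether methoxy behaves alike with methyl in place of trifluoromethyl also stays open.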